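Swapping a sulfonyl for a urea-type group on the piperazine

The source may report more compounds than this note shows. Statements on the series, on what has been measured and on what is new or still open speak of the compounds shown alone.

Measured in a functional assay on MDA-MB-436 cells (Homo sapiens) for antiproliferative activity, read by MTT assay, with a stated time of 48 h; on this read-out higher numbers stand for weaker inhibition and lower numbers for stronger inhibition:
Compound 1 `C=CS(=O)(=O)N1CCN(c2ccn3ncc(-c4ccccc4)c3n2)CC1`: 19500 nM
Compound 2 `C=CS(=O)(=O)N1CCN(c2nc(OC[C@H]3CCCN3C)nc3sccc23)CC1`: > 50000 nM
Compound 3 `CCS(=O)(=O)N1CCN(c2ncnc3sc(-c4ccc(N5CCN(C)CC5)cc4)cc23)CC1`: 10600 nM

A lower number here means stronger inhibition of cell growth. Compound 3 gives 10600 nM and compound 1 gives 19500 nM, two numbers within the usual scatter of each other, so neither can be called the stronger. For compound 2 the entry > 50000 nM is a limit of the assay and not a number.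

Compound 4 `COc1ccc(NC(=O)N2CCN(c3ncnc4sc(-c5ccc(N6CCN(C)CC6)cc5)cc34)CC2)cc1` keeps the rest of compound 3 and carries (4-methoxyphenyl)carbamoyl in place of ethylsulfonyl on an amine nitrogen in a ring. For the measured compounds named here, no pair of measured compounds tests this exchange, so the expectation starts from compound 3 at 10600 nM and stays close to it. The expected step in this assay is a 1.2-fold lower number from compound 3 to compound 4 (0.07 log units; within the scatter), which would be no change beyond the scatter, though the uncertainty is wide in both directions. Compound 4 is estimated at 9000 nM, with an expected range of 2500 nM to 35000 nM.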

Compound 4, half-maximal inhibitory concentration: 30100 nM
The estimate for compound 4 lay 3.3-fold (0.52 log units) below the measured number, within the range that was stated.
By their numbers in this assay, from the lowest: compounds 3, 1 and 4 (each within the scatter of the next, the first and the last beyond it). At a limit, above all of these: compound 2.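

In this assay, with the rest of the molecule held fixed, the group on this ring nitrogen does affect the result: the exchange gives a 2.8-fold higher number from compound 3 to compound 4 (0.45 log units; beyond the scatter) and so weakens growth inhibition. The exchange swaps ethylsulfonyl, which has no ring, for (4-methoxyphenyl)carbamoyl, which brings a six-membered aromatic ring and a hydrogen-bond donor, so several features change in one step and the step cannot assign the weakening to any one of them. Nothing measured here accounts for the rise.

Still open, on these data alone, is whether the carbamoyl link or the added aromatic ring accounts for the change. A small acetyl group, or a plain dimethylcarbamoyl group without the ring, on the same nitrogen would help to separate the two.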